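The source may report more compounds than this note shows. Statements on the series, on what has been measured and on what is new or still open speak of the compounds shown alone.

Compound 1 `O=C1C(Nc2ccccc2F)=CC(=O)c2c1nc1n2[C@H]2OC[C@@H](O)[C@H]2OC1` carries a 2-fluorophenyl group on an amine nitrogen of the shared core. In a functional assay on MCF7 cells (Homo sapiens) for inhibition, read by sulforhodamine B assay (a higher number here means a weaker inhibitor, a lower number a stronger inhibitor), compound 1 gives only a limit, > 4000 nM, and no number, so its standing is known from one side alone: the limit of > 4000 nM in this assay, at which 1 of the 2 values shown sits. Compound 2 `O=C1C=C(Nc2ccc(Br)cc2)C(=O)c2c1nc1n2[C@H]2OC[C@@H](O)[C@H]2OC1` is a related analogue from the same set, and in this assay compound 2 gives 2580 nM. Among the compounds with values here, no step between two measured compounds that differ in a single place is available, so the two values can only be set side by side: both point to weak inhibition, and compound 2 gives a number where compound 1 gives a limit.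

Compound 3 `O=C1C(Nc2cccc(F)c2)=CC(=O)c2c1nc1n2[C@H]2OC[C@@H](O)[C@H]2OC1` is the compound to be measured. Compared with compound 1 the change is 3-fluorophenyl in place of 2-fluorophenyl on an amine nitrogen. With compound 1 already at the limit, the step from compound 1 to compound 3 is expected to be no larger than the scatter, a step that the limit leaves unreadable from compound 1 to compound 3, in either direction. In this assay compound 3 is therefore expected to give about 4500 nM, with a likely range from 1500 nM to 13000 nM, and a fair chance that only a limit is reported again.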

Compound 3, half-maximal inhibitory concentration: > 4000 nM
Compound 3: only a limit was reported; the forecaster's own chance of this, stated with the estimate: 55%; the middle value is on the limit's open side.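

In this assay, within the data shown here, compound 3, like compound 1, gives only a limit, so no step from compound 1 to compound 3 can be read: the limit of > 4000 nM in this assay, at which 2 of the 3 values shown sit.

The compounds shown leave open how far compound 1 and compound 3 lie beyond that limit, and whether in this assay the 3-fluorophenyl and 2-fluorophenyl groups differ at all.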